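Swapping Acetyl for Dimethylamino on a Shared Core

The source may report more compounds than this note shows. Statements on the series, on what has been measured and on what is new or still open speak of the compounds shown alone.

Compound 1 `COc1cc(C)cc(-c2c(-c3ccnc(-c4ccc(C(C)=O)cc4)c3)cnn2CC#N)c1` and compound 2 `COc1cc(C)cc(-c2nn(CC#N)cc2-c2ccc(-c3cccc(C(C)=O)c3)nc2)c1` share one core and were both tested in a functional assay on NCI-H226 cells (Homo sapiens) for cytotoxicity, read by sulforhodamine B assay, with a stated time of 48 h, tested at 0.001 uM; a lower number here means a stronger effect, a higher number a weaker effect of the compound at the concentration tested. Compound 1 gives 100%, the highest of the two numbers, and compound 2 gives 95%, a number within the scatter of compound 1, so the two cannot be set apart on this read-out. Going by the values given here, no step between measured compounds is available for this pair. Compound 3 `COc1cc(C)cc(-c2c(-c3ccnc(-c4ccc(N(C)C)cc4)c3)cnn2CC#N)c1` has not yet been measured. It differs from compound 1 in one place: dimethylamino in place of acetyl on an aromatic carbon. With both measured values standing near the top of the scale, compound 3 is expected to stay there as well, and the step of a number 3 percentage points lower from compound 1 to compound 3 (within the scatter) is estimated to be none beyond the scatter. Because compound 1 gives 100%, compound 3 is expected to give 97%, with a range from 85% to 106%.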

Compound 3, a percentage reported as activity, at one concentration (the size of the read-out at that concentration, not a potency): 95%
The estimate for compound 3 lay 2 percentage points above the measured number; low and high end bracket the measured number.
By their numbers in this assay, from the lowest: compounds 2, 3 and 1 (each within the scatter of the next).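

Going by these compounds alone, exchanging acetyl for dimethylamino on an aromatic carbon, para to a large group, gives a number 5 percentage points lower from compound 1 to compound 3 (within the scatter) in this assay, and this is the only one-place comparison in the set. The 4-acetylphenyl and 4-(dimethylamino)phenyl forms therefore cannot be told apart on this read-out, even though one group carries a carbonyl oxygen and the other a nitrogen, with the same count of heavy atoms and hydrogen-bond acceptors. Nothing at hand bears on why the two groups give such similar numbers.

As far as these compounds go, whether a carboxylic acid, a primary amine or a longer alkyl chain at this position would move the number beyond the scatter remains open. Also open, from the compounds shown here alone, is whether compound 1 and compound 3 would separate at any concentration other than the single one tested.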